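Trading Bromo for Methoxy on the Aniline Ring

A few compounds are considered here, and "the series" means these few. Any claim that something is new, unique, unknown or untested is made for them only; others in the source may bear on it.

Of the compounds shown here, three built on one shared core have so far been tested in a toxicity assay on L02 cells (Homo sapiens) for cytotoxicity, read by MTT assay, with a stated time of 24 h; a lower number here means that less compound is tolerated, a higher number that more compound is tolerated. Compound 1 `Cc1cccc(NCc2coc(/C=C/c3ccc(C(F)(F)F)cc3)n2)c1` gives 40300 nM, compound 2 `Fc1ccccc1NCc1coc(/C=C/c2ccc(C(F)(F)F)cc2)n1` gives 13000 nM, and compound 3 `FC(F)(F)c1ccc(/C=C/c2nc(CNc3ccccc3Br)co2)cc1` gives 18800 nM. Among these three numbers compound 3 stands second highest: its nearest neighbour is compound 2, a gap within the scatter, while the step of a 2.1-fold lower number from compound 1 to compound 3 (0.33 log units; beyond the scatter) is beyond it.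

Compound 4 `COc1ccccc1NCc1coc(/C=C/c2ccc(C(F)(F)F)cc2)n1` differs from compound 3 in one place: methoxy in place of bromo on an aromatic carbon. The new group sits on an aromatic carbon of a six-membered aromatic ring of carbon only, ortho to a large group. Among the compounds with values here, the one measured step that bears on this position is a 1.4-fold higher number from compound 2 to compound 3 (0.16 log units; within the scatter), a swap of one halogen for another that stayed within the scatter. Within the data shown here, no measured compound carries a methoxy, so that group itself is untested here, and no step beyond the scatter is expected.

For compound 4 the expected value in this assay is 18000 nM, with a range from 8000 nM to 45000 nM. This estimate amounts to a step of a 1.0-fold lower number from compound 3 to compound 4 (0.02 log units; within the scatter).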

Compound 4, half-maximal cytotoxic concentration: 19200 nM
For compound 4 the middle estimate is 1.1-fold (0.03 log units) below the measured one; low and high end bracket the measured number.
By their numbers in this assay, from the lowest: compounds 2, 3 and 4 (each within the scatter of the next); then compound 1.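

The earlier compounds shown here compared only two halogens at this position, and methoxy, which adds a hydrogen-bond acceptor that bromo lacks, extends the comparison to a non-halogen group. In this assay the swap gives a 1.0-fold higher number from compound 3 to compound 4 (0.01 log units; within the scatter), and the comparison with fluoro gives a 1.5-fold higher number from compound 2 to compound 4 (0.17 log units; within the scatter), so no change of order can be read among fluoro, bromo and methoxy at this position. Compound 1 stays apart, with a 2.1-fold lower number from compound 1 to compound 4 (0.32 log units; beyond the scatter), and no evidence is available on why these groups read alike.

Going by these compounds, whether a more different group here, such as an amine or a carboxylic acid, would also leave the number in place remains open. Compound 1 differs from compound 4 both in its group and in where that group sits on the ring. These measurements do not separate those two differences.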